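The compounds below may be only part of what the source reports. "The series", "measured", "known", "first", "only" and "open" are said of these compounds alone.

Compound 1 `c1ccc(-c2ccc(Cn3cncc3CNc3ccc(-c4onc5ccccc45)c(-c4ccccc4)c3)cc2)cc1`: > 10000 nM
Compound 2 `COC(=O)c1ccc(NCc2cncn2Cc2cccc(F)c2)cc1-c1ccccc1`: > 1000 nM
Compound 3 `N#Cc1ccc(NCc2cncn2Cc2ccc(-c3ccccc3)cc2N)cc1-c1ccccc1`: > 1000 nM

In a toxicity assay on NIH3T3 cells (Mus musculus) for cytotoxicity, read by resazurin assay (on this read-out lower numbers stand for an effect already at smaller amounts and higher numbers for an effect only at larger amounts of compound), compound 2 gives > 1000 nM, which is a limit of the assay and not a number. Compound 2 therefore sits at the limit of > 1000 nM in this assay, at which 2 of the 3 values shown sit, and compound 3 shares that limit with it. Compound 1 sits at the limit of > 10000 nM in this assay, at which 1 of the 3 values shown sits, also a limit rather than a number. Among the compounds with values here, none of the three compounds gives a measured value in this assay, so no step between measured compounds can be taken from them.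

Compound 4 is `COC(=O)c1ccc(NCc2cncn2Cc2ccccc2C)cc1-c1ccccc1`. It differs from compound 2 in one place: 2-methylphenyl in place of 3-fluorophenyl on a saturated chain carbon bound to an aromatic nitrogen. Within the data shown here, since every value in this assay so far is a limit, nothing suggests that this exchange should move the read-out beyond the usual scatter in either direction. Compound 4 is expected to remain at or past the limit, the estimated step being a step that the limit leaves unreadable from compound 2 to compound 4. For compound 4 the estimate in this assay is 3000 nM, with a range from 1000 nM to 20000 nM.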

Compound 4, half-maximal effective concentration: 10000 nM
For compound 4 the middle estimate is 3.3-fold (0.52 log units) below the measured one, and the stated range covers the measured number.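

In this assay, within the data shown here, compound 2 gives > 1000 nM, which is a limit and not a number, so no step from it to compound 4 can be read. The compounds shown leave open how far, if at all, exchanging 3-fluorophenyl for 2-methylphenyl moves the read-out.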